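Acyl group on the ring nitrogen: aryl versus alkyl

The compounds below may be only part of what the source reports. "The series", "measured", "known", "first", "only" and "open" are said of these compounds alone.

The shared core is that of compound 2 `O=C(Nc1ccccc1C(F)(F)F)C1CCc2ccccc2N1C(=O)c1ccc(Cl)cc1`, an amide whose ring nitrogen carries an acyl group. Among the measured compounds shown here, in a functional assay on NUGC-3 cells (Homo sapiens) for cytotoxicity, read by sulforhodamine B assay, with a stated time of 72 h (on this read-out lower numbers stand for stronger inhibition of growth and higher numbers for weaker inhibition of growth), compound 2 gives 551 nM, the only number among the values shown here. Compound 1 `CCCC(=O)N1c2ccccc2CCC1C(=O)Nc1ccccc1C(F)(F)F` carries propyl on that carbonyl carbon instead. In this assay compound 1 gives > 70000 nM, which is a limit of the assay and not a number. For the measured compounds named here, the one measured step is an at least 120-fold lower number from compound 1 to compound 2 (2.10 log units; beyond the scatter), and it rests on (the limit of > 70000 nM in this assay, at which 1 of the 2 values shown sits).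

Compound 3 `CC(=O)N1c2ccccc2CCC1C(=O)Nc1ccccc1C(F)(F)F` is the next variation: methyl in place of 4-chlorophenyl on a carbonyl carbon. This change runs against the measured step, and methyl is a shorter chain than propyl. Because an at least 120-fold lower number from compound 1 to compound 2 (2.10 log units; beyond the scatter) came with the aryl group entering, its loss in compound 3 is expected to bring a large rise in the number, back toward where compound 1 sits. The expected step is a 130-fold higher number from compound 2 to compound 3 (2.10 log units; beyond the scatter). For compound 3 the estimate in this assay is 70000 nM, with a range from 8000 nM to 300000 nM, and a limit rather than a number is likely.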

Compound 3, concentration for 50% growth inhibition: > 80000 nM
Compound 3 ended at the assay's limit; the forecaster's own chance of this, stated with the estimate: 70%; middle value at least 1.1-fold (0.05 log units) away from the limit.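

Methyl in place of 4-chlorophenyl on the carbonyl carbon gives an at least 140-fold higher number from compound 2 to compound 3 (2.16 log units; beyond the scatter) in this assay, so the loss of growth inhibition now appears with a second alkyl group and not with propyl alone. Among the compounds shown here, compound 3 sits at a limit of the assay, which is not a number: the limit of > 80000 nM in this assay, at which 1 of the 3 values shown sits. Compound 1 and compound 3 cannot be ordered, as the step between them cannot be read, so these notes support no trend with chain length; at this position, the only readable number among the three compounds belongs to compound 2, the one carrying the aryl group.

The compounds shown leave open whether the step follows the aromatic ring or the chlorine, which a plain phenyl and a cyclohexyl on the same carbonyl carbon would help to separate. Also open, from the compounds shown here alone, is whether a longer chain such as octyl at this position would give a readable number in this assay, or would stay at a limit like the methyl and propyl compounds.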